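Trifluoromethyl for Methoxy on the Terminal Ring

This account rests on a few compounds, and the source may have more. Where it says the series, first, only, none or still open, it means among the compounds named here.

The series shares a core of two aromatic rings linked by an alkyne, with a second alkyne carrying a chain that ends in a hydroxyl. Compound 1 `OCCCCC#Cc1ccccc1C#Cc1ccccc1C(F)(F)F` bears a trifluoromethyl group; in a functional assay on SF-295 cells (Homo sapiens) for cytotoxicity (on this read-out higher numbers stand for weaker inhibition of growth and lower numbers for stronger inhibition of growth), compound 1 gives 2300 nM. Compound 2 `COc1cccc(C#Cc2ccccc2C#CCCCCO)c1` carries a methoxy group instead; in this assay compound 2 gives 7900 nM, the highest of the two numbers measured. Compound 1 sits lower, and that gap lies beyond the usual scatter.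

Compound 3 `OCCCCC#Cc1ccccc1C#Cc1cccc(C(F)(F)F)c1` differs from compound 2 by a single change: trifluoromethyl in place of methoxy on an aromatic carbon. Among the measured compounds shown here, no step between measured compounds matches this change exactly, so the expectation rests on the two numbers at hand. Compound 3 is expected to move toward the lower number of the pair, a step of moderate size in the direction of stronger growth inhibition, a 2.3-fold lower number from compound 2 to compound 3 (0.35 log units; beyond the scatter), because compound 1 with its trifluoromethyl gives 2300 nM. Compound 3 is therefore estimated at 3500 nM in this assay, within a range from 1500 nM to 8000 nM.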

Compound 3, concentration for 50% growth inhibition: 16500 nM
Compound 3: the middle estimate sits 4.7-fold (0.67 log units) below what was measured; the measured number lies above the stated range.
By their numbers in this assay, from the lowest: compound 1; then compound 2; then compound 3.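

On the aromatic carbon meta to a large group, trifluoromethyl in place of methoxy weakens growth inhibition in this assay, with a 2.1-fold higher number from compound 2 to compound 3 (0.32 log units; beyond the scatter), a modest step. Among the compounds shown here, this is the first direct reading of the change at this position, and it shows that carrying a trifluoromethyl group does not by itself give the lower number: compound 1 gives 2300 nM, while compound 3, with the same group at a different carbon of the terminal ring, gives 16500 nM, so the printed values differ with where the group stands. Nothing measured here bears on why the exchange moves the number in this direction.

For the compounds shown here, what the compounds leave open is whether methoxy would give a similar number at the carbon that holds trifluoromethyl in compound 1, since only one group has been seen at each of these two positions. Also open, on these data alone, is how other groups at the position of compound 3, such as an amine, a carboxylic acid or a nitrile, would compare with methoxy and trifluoromethyl.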